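Adding methoxycarbonyl to the methylamino arm of compound 2

The source may hold more compounds than are shown below. What is called first, only, known or untested is meant among the compounds shown, and "the series" means these compounds.

In a functional assay on HCT-116 cells (Homo sapiens) for cytotoxicity, read by MTT assay, with a stated time of 72 h (a lower number here means a stronger inhibitor, a higher number a weaker inhibitor), compound 1 (`C[C@@H](Nc1c(C(=O)NCc2ccc(F)cc2)nc(Br)c2cccnc12)c1ccccc1`) reads > 20000 nM as a limit of the assay. Compound 2 (`CNc1c(C(=O)NCc2ccc(F)cc2)nc(Br)c2cccnc12`) reads > 20000 nM as a limit too, so it has no number of its own. Among the compounds with values here, the only measured step is a step that the two limits leave unreadable from compound 1 to compound 2 and it gives no size to carry forward. The whole record so far is the limit of > 20000 nM in this assay, at which 2 of the 2 values shown sit, and nothing in the series has yet reached a readable number.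

The next compound is compound 3 (`COC(=O)CNc1c(C(=O)NCc2ccc(F)cc2)nc(Br)c2cccnc12`). The difference from compound 2 is methoxycarbonyl in place of hydrogen on a saturated chain carbon bound to a nitrogen on an aromatic ring and it turns methyl into (methoxycarbonyl)methyl, so methylamino becomes ((methoxycarbonyl)methyl)amino.

A clear gain in this assay is not expected because the limit of > 20000 nM in this assay, at which 2 of the 2 values shown sit, holds for both groups tried so far on this nitrogen. The only direction that could be read is toward a stronger inhibitor, and the estimated step is a number no higher from compound 2 to compound 3 (the limit leaves the size open) with no large change expected. For compound 3 the expected value is 20000 nM with an estimated range of 7000 nM to 40000 nM and a reading at the same limit as the likeliest outcome.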

Compound 3, half-maximal inhibitory concentration: > 10000 nM
Compound 3: only a limit was reported (the forecaster's own chance of this, stated with the estimate: 70%); the middle value does not contradict the limit.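

In this assay compound 3 gives > 10000 nM, which is a limit and not a number. Within the data shown here, compound 1, compound 2 and compound 3 all read as limits, so no step among them can be read. The compounds shown leave open whether any group on this nitrogen gives a readable number in this assay.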